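A few compounds are considered here, and "the series" means these few. Any claim that something is new, unique, unknown or untested is made for them only; others in the source may bear on it.

Measured in a functional assay on JM1 cells (Homo sapiens) for cytotoxicity; a higher number here means that more compound is tolerated, a lower number that less compound is tolerated:
- Compound 1 `CSCO[C@@]1(C)CO[C@@](C)(CC(=O)OC[C@H]2O[C@@H](n3cc(C)c(=O)[nH]c3=O)C[C@@H]2O)C1`: 400000 nM
- Compound 2 `CC1=CN([C@H]2C[C@H](O)[C@@H](COC(=O)C[C@@]3(C)C[C@@](C)(O)CO3)O2)C(=O)NC1`: > 500000 nM

For compound 2, the reading of > 500000 nM is a limit of the assay and not a number. Compound 1 does have a number, 400000 nM, so this assay can return a reading in this high range.

Compound 3 `Cc1cn([C@H]2C[C@H](O)[C@@H](COC(=O)C[C@@]3(C)C[C@@](C)(O)CO3)O2)c(=O)[nH]c1=O` differs from compound 2 in one place, on a saturated ring carbon of a five-membered non-aromatic ring with 1 oxygen, next to the ring oxygen: a group of 9 heavy atoms (5 carbon, 2 nitrogen, 2 oxygen; one six-membered aromatic ring with 2 hetero atoms) in place of a group of 8 heavy atoms (5 carbon, 2 nitrogen, 1 oxygen; one six-membered non-aromatic ring with 2 hetero atoms), on a saturated ring carbon. A group with one six-membered aromatic ring with 2 hetero atoms takes the place of a group with one six-membered non-aromatic ring with 2 hetero atoms.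

Among the measured compounds shown here, no measured pair shows what this exchange does, so the expectation rests only on the high readings of the two measured compounds. The expected step of a number no higher from compound 2 to compound 3 (the limit leaves the size open) in this assay is none beyond the usual scatter. Another limit rather than a number is quite likely. For compound 3 the estimated value is 500000 nM, with an expected range of 200000 nM to 900000 nM.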

Compound 3, half-maximal cytotoxic concentration: > 1000000 nM
Compound 3: only a limit was reported; the forecaster's own chance of this, stated with the estimate: 70%; middle value at least 2.0-fold (0.30 log units) away from the limit.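

In this assay compound 3 gives > 1000000 nM, which is a limit of the assay and not a number, so the aromatic ring at this saturated ring carbon leaves the reading as a limit, as the non-aromatic ring did. The exchange between the two rings cannot be sized, because both readings are limits: the limit of > 1000000 nM in this assay, at which 1 of the 3 values shown sits.

Compound 3 does give one readable comparison, at a different place in the molecule: hydrogen in place of (methylsulfanyl)methyl on an oxygen on a saturated carbon brings an at least 2.5-fold higher number from compound 1 to compound 3 (0.39 log units; beyond the scatter).

Still open, from the compounds shown here alone, is whether the two rings differ at all in this assay, since neither compound 2 nor compound 3 has a number, and how a group such as a primary amine would read at this ring carbon. Also open, going by these compounds, is whether a plain methyl on that oxygen would read like the hydrogen of compound 3 or like the (methylsulfanyl)methyl of compound 1, which would show whether any group there lowers the tolerated amount.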